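This account rests on a few compounds, and the source may have more. Where it says the series, first, only, none or still open, it means among the compounds named here.

Measured so far:
- compound 1, `c1ccc(Cn2nnc3c(NC4CCCCC4)ncnc32)cc1`, an assay on cell membranes for binding affinity to adenosine receptor A1 (Bos taurus), read by radioligand binding; a lower number here means a stronger inhibitor, a higher number a weaker inhibitor: 121 nM
- compound 2, `CC1CCCC(Nc2ncnc3c2nnn3Cc2ccccc2Cl)C1`, this assay: 102 nM

Of the compounds shown here, two of the shared core have been measured. Compound 1 gives 121 nM and compound 2 gives 102 nM; the gap between them is within the scatter of repeated measurements, so the two numbers are not distinguished, and neither can be called stronger or weaker on what is shown. For the measured compounds named here, no pair of measured compounds differs in one place, so no single step is available as a guide.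

Compound 3 is `CC(Nc1ncnc2c1nnn2Cc1ccccc1)c1ccccc1`. Relative to compound 1 it carries 1-phenylethyl in place of cyclohexyl on a nitrogen on an aromatic ring. The change keeps the count of hydrogen-bond donors and acceptors and the charge unchanged, and exchanges a saturated six-membered ring for an aromatic one with an added carbon bearing the attachment. With no measured step of this kind in the series, the expectation is a step of no more than the scatter, if anything toward a slightly lower number. For compound 3 the estimated value in this assay is 90 nM, with a range from 30 nM to 300 nM, which from compound 1 means an expected step of a 1.3-fold lower number from compound 1 to compound 3 (0.13 log units; within the scatter).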

Compound 3, inhibition constant: 438 nM
Compound 3: the middle estimate sits 4.9-fold (0.69 log units) below what was measured; the whole stated range lies below it.
By their numbers in this assay, from the lowest: compounds 2 and 1 (each within the scatter of the next); then compound 3.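

In this assay, the change to 1-phenylethyl in place of cyclohexyl on a nitrogen on an aromatic ring gives a 3.6-fold higher number from compound 1 to compound 3 (0.56 log units; beyond the scatter), the first single-place step available in the series and one that lies beyond the scatter. This position is therefore not indifferent to the group it carries, even though the two groups match in their hydrogen-bond donors and acceptors and neither bears a net charge; they differ in ring type and in size, with 8 heavy atoms entering and 6 leaving. Nothing available bears on the origin of this step.

A single step cannot separate the exchange of the saturated ring for the aromatic one from the two extra carbons, and a plain benzyl or phenyl group on the same nitrogen would be needed to tell those contributions apart. Going by these compounds, compound 2 differs from compound 1 in more than one place, so the separate contributions of its methyl and chlorine remain open, as does whether a polar group on this nitrogen substituent, such as a hydroxyl or an amine, would be tolerated.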